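The source may hold more compounds than are shown below. What is called first, only, known or untested is meant among the compounds shown, and "the series" means these compounds.

Compound 1 `CC1(COc2ccc(-c3ccc(F)nc3F)nc2)CCn2cc([N+](=O)[O-])nc2O1`: > 64000 nM
Compound 2 `O=[N+]([O-])c1cn2c(n1)OC(COc1ccc(-c3ccc(F)nc3F)cn1)CC2`: > 64000 nM
Compound 3 `O=[N+]([O-])c1cn2c(n1)OC(COc1ccc(-c3ccc(F)cc3F)cn1)CC2`: > 64000 nM

All three were tested in an ADME assay on MRC5 cells (Homo sapiens) for cytotoxicity, read by resazurin assay, with a stated time of 72 h; on this read-out lower numbers stand for stronger inhibition and higher numbers for weaker inhibition. For compound 1 the value is only a limit of the assay, not a number. The same holds for compound 2. The same holds for compound 3, so the limit of > 64000 nM in this assay, at which 3 of the 3 values shown sit, is the whole picture so far. Between compound 2 and compound 3 the change is 2,4-difluorophenyl in place of 2,6-difluoropyridin-3-yl on an aromatic carbon, and the step that the two limits leave unreadable from compound 2 to compound 3 therefore cannot be read. Compound 4 `CC1(COc2ccc(-c3ccc(F)cc3F)nc2)CCn2cc([N+](=O)[O-])nc2O1` is not yet measured. It differs from compound 1 by 2,4-difluorophenyl in place of 2,6-difluoropyridin-3-yl on an aromatic carbon, the same kind of change, though here the place is next to the ring nitrogen whereas in compound 3 it is two atoms from the ring nitrogen. How the core of compound 1 differs from the core of compound 2 is not broken down here. In this assay the expected step is a step that the limit leaves unreadable from compound 1 to compound 4. That expectation rests on (the limit of > 64000 nM in this assay, at which 3 of the 3 values shown sit), where compound 1 and compound 3 both sit, so the change seen in compound 3 did not bring a number. Compound 4 is therefore estimated at 100000 nM, with a range from 50000 nM to 300000 nM.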

Compound 4, half-maximal inhibitory concentration: > 64000 nM
Compound 4: no number, only a limit (the forecaster's own chance of this, stated with the estimate: 90%); the middle value lies beyond the limit too.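

Compound 4 gives > 64000 nM and that is a limit of the assay, not a number. Compound 1 also sits at a limit, so no step can be read between compound 1 and compound 4: the limit of > 64000 nM in this assay, at which 4 of the 4 values shown sit. The compounds shown leave open whether 2,4-difluorophenyl in place of 2,6-difluoropyridin-3-yl changes cytotoxicity at all, and at what concentration any of them would inhibit these cells.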